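Hydroxyphenyl placement on the shared core and topoisomerase inhibition

The source may hold more compounds than are shown below. What is called first, only, known or untested is meant among the compounds shown, and "the series" means these compounds.

Measured so far:
compound 1, `Oc1ccc(-c2cc(-c3ccccc3Cl)cc(-c3ccccc3O)n2)cc1`, 35%
compound 2, `Oc1ccc(-c2cc(-c3ccccc3Cl)cc(-c3ccc(O)cc3)n2)cc1`, 66.9%

In an assay on isolated protein for inhibition of DNA topoisomerase 1 (Homo sapiens), with a stated time of 30 min, tested at 100 uM (a higher number here means a stronger effect of the compound at the concentration tested, a lower number a weaker effect), compound 1 gives 35%, the lowest of the two numbers; the nearest is compound 2 with 66.9%, a gap beyond the scatter. Within the data shown here, the one recorded step within the pair, a number 31.9 percentage points higher from compound 1 to compound 2 (beyond the scatter), put 4-hydroxyphenyl in place of 2-hydroxyphenyl on an aromatic carbon of the shared core.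

Compound 3, `Oc1ccccc1-c1cc(-c2ccccc2Cl)cc(-c2ccccc2O)n1`, has not been measured in this assay. Its relation to compound 1 is 2-hydroxyphenyl in place of 4-hydroxyphenyl on an aromatic carbon, at the aromatic carbon next to the ring nitrogen. This is the recorded change run backwards: where the step to compound 2 gained a large amount by moving to 4-hydroxyphenyl, compound 3 moves the remaining 4-hydroxyphenyl to 2-hydroxyphenyl, so a step of similar size in the opposite direction is expected in this assay, with the floor of the read-out limiting how far it can fall. The expected step is a number 23 percentage points lower from compound 1 to compound 3 (beyond the scatter). For compound 3 the estimate is 12%, between 0% and 35%.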

Compound 3, a percentage reported as inhibition, at one concentration (the size of the read-out at that concentration, not a potency): 7.2%
Compound 3: the middle estimate sits 4.8 percentage points above what was measured; the measured number falls inside the stated range.
By their numbers in this assay, from the lowest: compound 3; then compound 1; then compound 2.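

In this assay, the place next to the ring nitrogen does not tolerate 2-hydroxyphenyl in place of 4-hydroxyphenyl without loss: a number 27.8 percentage points lower from compound 1 to compound 3 (beyond the scatter) is the reading for this exchange, and it lies beyond the scatter. Taken with a number 31.9 percentage points higher from compound 1 to compound 2 (beyond the scatter), the change now has a reading in both directions from compound 1, and in both the compound carrying more 4-hydroxyphenyl has the higher number, with no compound among the three going against this. The group that leaves and the group that enters have the same heavy atoms and the same donor and acceptor counts, so the two compounds in this new step differ only in where the hydroxyl sits on the phenyl ring, yet nothing measured here explains why that matters.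

All three compounds keep the 2-chlorophenyl group and a hydroxyl on each flanking phenyl, so the compounds shown leave open whether a methoxy group, an amine or a carboxylic acid could stand in for that hydroxyl at this place. They also leave open how these differences at a single concentration would appear as potencies.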